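This account rests on a few compounds, and the source may have more. Where it says the series, first, only, none or still open, it means among the compounds named here.

Compound 1 `O=C(CSc1nc(Nc2ccccc2)c2ccccc2n1)Nc1ccccc1F`, compound 2 `O=C(CSc1nc(Nc2ccccc2)c2ccccc2n1)Nc1cccc(Cl)c1` and compound 3 `O=C(CSc1nc(Nc2ccccc2)c2ccccc2n1)Nc1cccc(Br)c1` share one core and differ only in the aryl group carried on the amide-type nitrogen. In a functional assay on MDA-MB-231 cells (Homo sapiens) for inhibition, read by MTT assay, with a stated time of 72 h (on this read-out higher numbers stand for weaker inhibition and lower numbers for stronger inhibition), compound 1 gives > 50000 nM, which is a limit of the assay rather than a number (the limit of > 50000 nM in this assay, at which 1 of the 3 values shown sits). In this assay compound 2 gives 16500 nM and compound 3 gives 17500 nM. Among the two numbers shown, compound 3 sits within the scatter of compound 2: there is a 1.1-fold higher number from compound 2 to compound 3 (0.03 log units; within the scatter). Against compound 1 the steps are larger, an at least 3.0-fold lower number from compound 1 to compound 2 (0.48 log units; beyond the scatter) and an at least 2.8-fold lower number from compound 1 to compound 3 (0.45 log units; beyond the scatter).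

Compound 4 `O=C(CSc1nc(Nc2ccccc2)c2ccccc2n1)Nc1ccc(Cl)c(Cl)c1` is not yet measured. It differs from compound 3 by 3,4-dichlorophenyl in place of 3-bromophenyl on an amide-type nitrogen. Going by the values given here, the one measured step that bears directly on this change is the bromo-to-chloro swap, a 1.1-fold higher number from compound 2 to compound 3 (0.03 log units; within the scatter), which stayed within the scatter. Among the compounds with values here, no measured step shows what a second chloro on the entering 3,4-dichlorophenyl does, so the expectation rests on that one step alone. Compound 4 is therefore expected to give a number close to that of compound 3, with at most a small lowering, a 1.5-fold lower number from compound 3 to compound 4 (0.16 log units; within the scatter). The estimate for compound 4 in this assay is 12000 nM, with a range from 5000 nM to 30000 nM.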

Compound 4, half-maximal inhibitory concentration: 14500 nM
Estimate against measurement, compound 4: 1.2-fold (0.08 log units) below; measured number inside the range.
By their numbers in this assay, from the lowest: compounds 4, 2 and 3 (each within the scatter of the next). At a limit, above all of these: compound 1.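

In this assay, a second halogen on the aryl group leaves the number within the scatter: chloro in place of hydrogen gives a 1.1-fold lower number from compound 2 to compound 4 (0.06 log units; within the scatter), and 3,4-dichlorophenyl in place of 3-bromophenyl gives a 1.2-fold lower number from compound 3 to compound 4 (0.08 log units; within the scatter). The 3-chlorophenyl, 3-bromophenyl and 3,4-dichlorophenyl compounds therefore form a single level at this amide-type nitrogen, and the 3,4-dichlorophenyl group joins the other two in standing apart from the 2-fluorophenyl group, with an at least 3.4-fold lower number from compound 1 to compound 4 (0.53 log units; beyond the scatter). The size of that gap is only a bound, since the value of compound 1 is a limit of the assay and not a number: the limit of > 50000 nM in this assay, at which 1 of the 4 values shown sits.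

The compounds shown leave open whether a group other than a halogen on this aryl ring, such as a methoxy, a carboxylic acid or a dimethylamino group, would lower the number beyond the scatter. They also leave open whether a 3-fluorophenyl or a 2-chlorophenyl group would side with compound 1 or with the other three, which would separate the effect of the halogen from that of its place on the ring.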